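Swapping 4-chlorobenzyl for acetyl on compound 3

This account rests on a few compounds, and the source may have more. Where it says the series, first, only, none or still open, it means among the compounds named here.

Compound 1 (`O=C(NCC1COc2cnccc21)C1CCN(C(=O)c2cc3ccccc3n2Cc2ccc(Cl)cc2)CC1`) gives 75800 nM
Compound 2 (`O=C(c1cc2ccccc2n1Cc1ccc(Cl)cc1)N1CCC(C(=O)N2CCOCC2)CC1`) gives > 100000 nM (a limit of the assay, not a number)
Compound 3 (`CN(Cc1ccccc1)C(=O)C1CCN(C(=O)c2cc3ccccc3n2Cc2ccc(Cl)cc2)CC1`) gives 87000 nM

In an ADME assay on BE(2)-C cells (Homo sapiens) for cytotoxicity, read by MTT assay, with a stated time of 20 h (a higher number here means that more compound is tolerated, a lower number that less compound is tolerated), compound 3 and compound 1 lie within the scatter of each other, while compound 2 offers only a limit. Compound 4 (`CC(=O)n1c(C(=O)N2CCC(C(=O)N(C)Cc3ccccc3)CC2)cc2ccccc21`) carries acetyl in place of 4-chlorobenzyl on an aromatic nitrogen. Every measured step changes the group on a carbonyl carbon instead (an at least 1.3-fold higher number from compound 1 to compound 2 (0.12 log units; that floor lies within the scatter)) and (a 1.1-fold higher number from compound 1 to compound 3 (0.06 log units; within the scatter)) and (an at least 1.1-fold lower number from compound 2 to compound 3 (0.06 log units; that floor lies within the scatter)), and none is shown beyond the scatter. Among the measured compounds shown here, these steps bear only indirectly on the new change, since no measured pair differs at this nitrogen. The estimate therefore starts from compound 3 (87000 nM), and no step beyond the scatter is expected in this assay, in either direction. The expected step is small (a 1.0-fold higher number from compound 3 to compound 4 (0.01 log units; within the scatter)). Compound 4 is estimated at 90000 nM (expected range 45000 nM to 180000 nM).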

Compound 4, half-maximal cytotoxic concentration: > 50000 nM
Compound 4 was reported as a limit (the forecaster's own chance of this, stated with the estimate: 40%); the middle value does not contradict the limit.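

In this assay compound 4 gives > 50000 nM, which is a limit of the assay and not a number. That leaves the step from compound 3 to compound 4 unreadable. The compounds shown leave open how far acetyl in place of 4-chlorobenzyl on the aromatic nitrogen shifts the tolerated concentration, if at all.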